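A few compounds are considered here, and "the series" means these few. Any claim that something is new, unique, unknown or untested is made for them only; others in the source may bear on it.

Measured compounds:
- compound 1, `Cc1c(C)c2c(c(C)c1O)CCC(C)(C(=O)NCCS)O2`, 1600 nM
- compound 2, `CCOC(=O)C(CS)NC(=O)C1(C)CCc2c(C)c(O)c(C)c(C)c2O1`, 3000 nM
- compound 3, `CCOC(=O)C(CS)NC(=O)/C=C/c1cc(C(C)(C)C)c(O)c(C(C)(C)C)c1`, 40000 nM

All three were tested in a functional assay on microsomes from liver (Rattus norvegicus) for inhibition, read by spectrophotometry, with a stated time of 45 min; on this read-out lower numbers stand for stronger inhibition and higher numbers for weaker inhibition. Compound 2 and compound 1 share a core and differ by one change, (hydrogen in place of ethoxycarbonyl on a saturated chain carbon bound to an amide-type nitrogen and a saturated chain carbon); the step between them, a 1.9-fold lower number from compound 2 to compound 1 (0.27 log units; within the scatter), lies within the scatter. Compound 3 rests on a different core; the difference between the two cores is not broken down here. In this assay compound 3 gives the highest of the three numbers, well apart from compound 2 and from compound 1.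

Compound 4, `CC(C)(C)c1cc(/C=C/C(=O)NCCS)cc(C(C)(C)C)c1O`, not yet measured, carries the same change on the core of compound 3: hydrogen in place of ethoxycarbonyl on a saturated chain carbon bound to an amide-type nitrogen and a saturated chain carbon. Because the step of a 1.9-fold lower number from compound 2 to compound 1 (0.27 log units; within the scatter) was small, a step of similar size, a 1.8-fold lower number from compound 3 to compound 4 (0.26 log units; within the scatter), is expected. Compound 4 is therefore estimated at 22000 nM, between 8000 nM and 55000 nM.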

Compound 4, half-maximal inhibitory concentration: 30000 nM
Compound 4: middle estimate off by 1.4-fold (0.13 log units), on the low side; measured number inside the range.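

In this assay, hydrogen in place of ethoxycarbonyl on the second core gives a 1.3-fold lower number from compound 3 to compound 4 (0.12 log units; within the scatter), a step that stays within the scatter. The change thus behaves alike on the two cores, neither step nor the gap between them standing out: the same change on two cores in this assay, a 1.9-fold lower number (0.27 log units; within the scatter) from compound 2 to compound 1 and a 1.3-fold lower number (0.12 log units; within the scatter) from compound 3 to compound 4, 1.4-fold (0.15 log units) apart, within the scatter of two such steps. This shows that, on these two cores, the change carries across without a measurable effect on the number, but it does not show that the same would hold on any further core, and two small steps give no ground for a wider rule.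

As far as these compounds go, it remains open whether a carboxylic acid or an amide in place of ethoxycarbonyl would behave the same way on either core. A longer chain in place of 2-sulfanylethyl, or a hydroxyl group in place of its sulfanyl group, is equally untested among the compounds shown.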